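Swapping the amine substituent on the piperidine of compound 2

The source may report more compounds than this note shows. Statements on the series, on what has been measured and on what is new or still open speak of the compounds shown alone.

Measured compounds:
- compound 1, `c1cc2[nH]cc(CCCN3CCCCC3)c2cc1-n1cnnc1`, an assay on CHO cells for binding affinity to 5-hydroxytryptamine receptor 1B (Homo sapiens); a lower number here means a stronger inhibitor, a higher number a weaker inhibitor: 15 nM
- compound 2, `CN(Cc1ccccc1)C1CCN(CCCc2c[nH]c3ccc(-n4cnnc4)cc23)CC1`, this assay: 145 nM

Compound 2 gives the higher of the two numbers in this assay, standing at a 9.7-fold higher number from compound 1 to compound 2 (0.99 log units; beyond the scatter); that step is the only one measured so far, and it shows that attaching benzyl(methyl)amino to the saturated ring weakens binding compared with compound 1.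

Compound 3, `C[C@@H](NC1CCN(CCCc2c[nH]c3ccc(-n4cnnc4)cc23)CC1)c1ccccc1`, has not yet been measured. It differs from compound 2 only in how the same atoms are joined: (1-phenylethyl)amino in place of benzyl(methyl)amino on a saturated ring carbon. For the measured compounds named here, no measured step covers this exact rearrangement, so the step from compound 1 to compound 2 is only a loose guide: it shows that a group of this kind at this position is tolerated but costs some affinity. With the same atom count and one hydrogen-bond donor gained, the change is expected to give a step within or near the usual scatter, with no direction clearly favoured, so the expected step is a 1.2-fold lower number from compound 2 to compound 3 (0.08 log units; within the scatter). On that basis compound 3 is estimated at 120 nM, with a likely range from 40 nM to 400 nM.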

Compound 3, half-maximal inhibitory concentration: 35 nM
Estimate against measurement, compound 3: 3.4-fold (0.54 log units) above; measured number outside the range, below it.
By their numbers in this assay, from the lowest: compound 1; then compound 3; then compound 2.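

In this assay the same atoms joined differently give a 4.1-fold lower number from compound 2 to compound 3 (0.62 log units; beyond the scatter) and this lies beyond the scatter, so on this saturated ring carbon the arrangement of the group matters and not only its atom count. The new value also refines the earlier reading of this position: a 2.3-fold higher number from compound 1 to compound 3 (0.37 log units; beyond the scatter) is a smaller cost than a 9.7-fold higher number from compound 1 to compound 2 (0.99 log units; beyond the scatter) so a large group here need not cost as much as compound 2 suggested, although compound 1, with hydrogen at this place, still gives the lowest number of the three. The change brings a hydrogen-bond donor and a defined stereocentre together, and nothing shown here separates their contributions or explains the shift.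

The compounds shown leave open whether the amine hydrogen alone accounts for the lower number, a question that plain benzylamino would address, since it keeps that hydrogen without the extra methyl group or the stereocentre. They also leave open how much the handedness matters, which the mirror-image form of the (1-phenylethyl)amino group would show.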